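The source may report more compounds than this note shows. Statements on the series, on what has been measured and on what is new or still open speak of the compounds shown alone.

Compound 2, with the structure `COc1cccc(-c2c(C)n(Cc3c(F)cccc3F)c(=O)n(C[C@H](C)N)c2=O)c1`, gives 18000 nM in an assay on HEK293 cells for binding affinity to Gonadotropin-releasing hormone receptor (Homo sapiens), read by radioligand binding (a lower number here means a stronger inhibitor, a higher number a weaker inhibitor), the highest of the two numbers recorded so far. Its closest neighbour is compound 1, `COc1cccc(-c2c(C)n(Cc3c(F)cccc3F)c(=O)n(C[C@@H](C)N)c2=O)c1`, which gives 2500 nM; the step from compound 1 to compound 2 is a 7.2-fold higher number from compound 1 to compound 2 (0.86 log units; beyond the scatter), and it rests on (the fact that compounds 1 and 2 differ only in the configuration as drawn).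

Compound 3, `COc1cccc(-c2c(C)n(Cc3c(F)cccc3F)c(=O)n(CC(C)N(C)CCCOCC(C)C)c2=O)c1`, differs from compound 2 in this way: 1-((3-(isobutoxy)propyl)(methyl)amino)ethyl in place of 1-aminoethyl on a saturated chain carbon bound to an aromatic nitrogen. The entering group carries no defined stereocentre, so compound 3 is not tied to one drawn configuration as compound 2 is. Going by the values given here, the only measured step, from compound 1 to compound 2, concerns configuration alone and does not test a change of the group on the amine nitrogen, so it bears on this step only loosely; it does suggest that a compound not fixed in the weaker configuration could sit closer to compound 1 than to compound 2. Compound 3 is therefore expected to show a step of a 4.5-fold lower number from compound 2 to compound 3 (0.65 log units; beyond the scatter), downward, though with little measured backing. For compound 3 the estimated value in this assay is 4000 nM, within a range from 500 nM to 30000 nM.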

Compound 3, inhibition constant: 240 nM
Compound 3: the middle estimate sits 17-fold (1.22 log units) above what was measured; the whole stated range lies above it.
By their numbers in this assay, from the lowest: compound 3; then compound 1; then compound 2.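

Compound 3 shows that this position, on a saturated chain carbon bound to an aromatic nitrogen, can carry far more than the small 1-aminoethyl group. In this assay, putting 1-((3-(isobutoxy)propyl)(methyl)amino)ethyl in its place gives a 75-fold lower number from compound 2 to compound 3 (1.88 log units; beyond the scatter), and the same comparison against the other drawn configuration gives a 10-fold lower number from compound 1 to compound 3 (1.02 log units; beyond the scatter), so the number falls below those of both earlier compounds, whichever configuration is taken. The earlier pair showed only that configuration at this carbon matters, with a 7.2-fold higher number from compound 1 to compound 2 (0.86 log units; beyond the scatter), and nothing shown here explains why the larger group lowers the number.

On these data alone, compound 3 is drawn without a defined configuration at this carbon, so it remains open how much each of its two forms contributes to the value, and whether the preference seen between compound 1 and compound 2 still holds with the larger group. As far as these compounds go, it is also open which part of the entering group matters, since a shorter chain, a chain without the ether oxygen, or a hydrogen in place of the methyl on the amine nitrogen would each separate these parts.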